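Three distal substituents measured, a fourth awaits its number

A few compounds are considered here, and "the series" means these few. Any claim that something is new, unique, unknown or untested is made for them only; others in the source may bear on it.

Three compounds share one core. Compound 1 `CC[C@H](C)[C@H](N)CN(C(=O)[C@@H]1C[C@H]1c1ccccc1)c1ccc(-c2ccc(CCC(=O)OC)cc2)cc1` gives 110 nM in a functional assay for agonist activity at G protein-coupled receptor 88 (Homo sapiens), read by HTRF and cAMP accumulation; a lower number here means that less compound is needed, a higher number that more compound is needed for the effect. Compound 2 `CC[C@H](C)[C@H](N)CN(C(=O)[C@@H]1C[C@H]1c1ccccc1)c1ccc(-c2ccc(C(=O)N(C)C)cc2)cc1` gives 980 nM, and compound 3 `CC[C@H](C)[C@H](N)CN(C(=O)[C@@H]1C[C@H]1c1ccccc1)c1ccc(-c2ccc(NS(C)(=O)=O)cc2)cc1` gives 1200 nM, the highest of the three numbers. The step of an 11-fold higher number from compound 1 to compound 3 (1.04 log units; beyond the scatter) and the step of a 1.2-fold higher number from compound 2 to compound 3 (0.09 log units; within the scatter) frame where compound 3 stands. Compound 4 `CC[C@H](C)[C@H](N)CN(C(=O)[C@@H]1C[C@H]1c1ccccc1)c1ccc(-c2ccc(CN(C)C)cc2)cc1` carries (dimethylamino)methyl in place of methanesulfonamido on an aromatic carbon. For the measured compounds named here, no measured step exchanges a methanesulfonamido group for a (dimethylamino)methyl group; the steps of an 8.9-fold higher number from compound 1 to compound 2 (0.95 log units; beyond the scatter) and an 11-fold higher number from compound 1 to compound 3 (1.04 log units; beyond the scatter) show only that two replacements of the ester chain gave similar numbers. The step of a 1.5-fold lower number from compound 3 to compound 4 (0.18 log units; within the scatter) is therefore expected to be small, within the usual scatter. The estimate for compound 4 is 800 nM, ranging from 150 nM to 4000 nM.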

Compound 4, half-maximal effective concentration: 460 nM
Beside the measured number, compound 4's estimate is 1.7-fold (0.24 log units) above it, and the stated range covers the measured number.
By their numbers in this assay, from the lowest: compound 1; then compound 4; then compounds 2 and 3 (each within the scatter of the next).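

In this assay the (dimethylamino)methyl group stands apart from both earlier replacements of the 2-(methoxycarbonyl)ethyl chain (a 2.6-fold lower number from compound 3 to compound 4 (0.42 log units; beyond the scatter); a 2.1-fold lower number from compound 2 to compound 4 (0.33 log units; beyond the scatter)), so this position does not respond alike to every such replacement. It still does not recover the number of the ester chain (a 4.2-fold higher number from compound 1 to compound 4 (0.62 log units; beyond the scatter)). Nothing available explains these differences. The compounds shown leave open whether a primary amine or a carboxylic acid at this position, or a longer chain ending in dimethylamino, would come closer to compound 1.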